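The compounds below may be only part of what the source reports. "The series", "measured", "known", "first", "only" and "open" are said of these compounds alone.

Measured in a functional assay on U-87MG ATCC cells for inhibition, with U-87 MG (Homo sapiens) as the target, read by MTT assay, with a stated time of 72 h; on this read-out lower numbers stand for stronger inhibition and higher numbers for weaker inhibition:
- compound 1 `COc1ccccc1-c1csc2cnc(Nc3ccc(NC(=O)C4CCNCC4)cc3)nc12` gives 1060 nM
- compound 2 `COc1ccccc1-c1csc2cnc(Nc3ccc(C(=O)NC4CCNCC4)cc3C)nc12` gives 250 nM
- compound 3 `CNC(=O)c1ccc(Nc2ncc3scc(-c4ccccc4OC)c3n2)cc1` gives 710 nM

Compound 1 sits with compound 3 at the upper end of these numbers, the two lying within the scatter of each other, while compound 2 stands lower, beyond the scatter. Next comes compound 4 `COc1ccccc1-c1csc2cnc(Nc3ccc(C(=O)NC4CCNCC4)cc3)nc12`, which has not yet been measured. It has the same atoms as compound 1, joined differently: (piperidin-4-yl)carbamoyl in place of ((piperidin-4-yl)carbonyl)amino on an aromatic carbon. In plain terms, the linking amide runs the other way round.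

Going by the values given here, one measured step bears on this: a 1.5-fold lower number from compound 1 to compound 3 (0.17 log units; within the scatter). That step also puts a carbamoyl group in this place, though a methylcarbamoyl, and on its own it suggests little change. Compound 2 is structurally closer, carrying the entering (piperidin-4-yl)carbamoyl group plus one extra methyl group, and compound 2 gives 250 nM. The data cannot show how much of the gap between these values belongs to that methyl group. A modest move toward a lower number is therefore expected in this assay, namely a 2.4-fold lower number from compound 1 to compound 4 (0.37 log units; beyond the scatter). Compound 4 is estimated at 450 nM, with an expected range from 180 nM to 1100 nM.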

Compound 4, half-maximal inhibitory concentration: 650 nM
For compound 4 the middle estimate is 1.4-fold (0.16 log units) below the measured one; the range from low to high includes it.
By their numbers in this assay, from the lowest: compound 2; then compounds 4, 3 and 1 (each within the scatter of the next).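

In this assay, running the linking amide the other way round, with the group on an aromatic carbon para to a large group, changes nothing that can be told from scatter: the step is a 1.6-fold lower number from compound 1 to compound 4 (0.21 log units; within the scatter). Swapping the small amide end for the larger one is just as flat, with piperidin-4-yl in place of methyl on the amide-type nitrogen giving a 1.1-fold lower number from compound 3 to compound 4 (0.04 log units; within the scatter), so across compounds 1, 3 and 4 neither the direction of the amide nor the piperidin-4-yl group shows up in the numbers. Going by these compounds alone, the one step beyond the scatter is the single change on the ring, hydrogen in place of methyl on an aromatic carbon, which gives a 2.6-fold higher number from compound 2 to compound 4 (0.41 log units; beyond the scatter), so the gap to compound 2 can now be placed on that one methyl group rather than on the amide.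

Nothing measured here speaks to why that methyl group matters. Also open, going by these compounds, is whether a methyl group would do the same on the reversed amide of compound 1, and whether a chlorine atom or a methoxy group in its place would give a number like that of compound 2.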